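The source may hold more compounds than are shown below. What is called first, only, known or untested is meant among the compounds shown, and "the series" means these compounds.

Compound 3 `Cc1cccc(-c2cccc(NCc3cncn3Cc3ccccc3)c2)c1` and compound 1 `Cc1cccc(-c2cccc(NCc3cncn3Cc3ccccc3)c2)c1C` share one core; compound 2 `c1ccc(-c2ccc(Cn3cncc3CNc3ccc(-c4nc5ccccc5s4)c(-c4ccccc4)c3)cc2)cc1` carries another, and the difference between the two cores is not broken down here. In a toxicity assay on NIH3T3 cells (Mus musculus) for cytotoxicity, read by resazurin assay (on this read-out higher numbers stand for an effect only at larger amounts of compound and lower numbers for an effect already at smaller amounts), compound 3 gives only a limit, > 1000 nM. In this assay compound 1 likewise gives only a limit, > 1000 nM. In this assay compound 2 also gives only a limit, > 1000 nM. Going by the values given here, the change from compound 3 to compound 1, (methyl in place of hydrogen on an aromatic carbon), therefore yields a step that the two limits leave unreadable from compound 3 to compound 1, since the limit of > 1000 nM in this assay, at which 3 of the 3 values shown sit, covers every value so far. Compound 4 `Cc1ccccc1-c1cc(NCc2cncn2Cc2ccc(-c3ccccc3)cc2)ccc1-c1nc2ccccc2s1` is unmeasured; it arises from compound 2 by methyl in place of hydrogen on an aromatic carbon, the same kind of change, though here the place reads only on an aromatic carbon of a six-membered aromatic ring of carbon only, ortho to a large group, without the added feature ortho to a methyl group (1 heavy atom) that the place of compound 1 shows. The step expected in this assay from compound 2 to compound 4 is a step that the limit leaves unreadable from compound 2 to compound 4, resting on (the limit of > 1000 nM in this assay, at which 3 of the 3 values shown sit). Compound 4 is accordingly expected near 2000 nM, most probably again reported only as a limit, between 700 nM and 10000 nM.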

Compound 4, half-maximal effective concentration: > 1000 nM
Compound 4: only a limit was reported (the forecaster's own chance of this, stated with the estimate: 85%); the middle value is on the limit's open side.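

In this assay, compound 2 and compound 4 are both reported only as limits, so no step can be read for methyl in place of hydrogen: the limit of > 1000 nM in this assay, at which 4 of the 4 values shown sit. The compounds shown leave open where any of them would reach a half-maximal effect, and whether this methyl change alters that concentration on either core.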